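A few compounds are considered here, and "the series" means these few. Any claim that something is new, unique, unknown or untested is made for them only; others in the source may bear on it.

Measured compounds:
Compound 1, `CC(C)(C)OC(=O)N1CCC(O[C@H]2CC[C@H](Oc3ccc(S(C)(=O)=O)c(F)c3)CC2)CC1`: in a functional assay on isolated protein for agonist activity at Glucose-dependent insulinotropic receptor (Rattus norvegicus), read by HTRF and cAMP accumulation (on this read-out lower numbers stand for an effect already at smaller amounts and higher numbers for an effect only at larger amounts of compound), compound 1 gives 167 nM.
Compound 2, `Cc1nc(O[C@H]2CC[C@H](OC3CCN(C(=O)OC(C)(C)C)CC3)CC2)ccc1C(=O)N(C)C`: in this assay compound 2 gives 400 nM.
Compound 3, `C[C@@H](CF)OC(=O)N1CCC(O[C@H]2CC[C@H](Oc3cnc(S(C)(=O)=O)cn3)CC2)CC1`: in this assay compound 3 gives 356 nM.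

Among these three numbers compound 3 holds the second highest. Compound 2 sits nearest to it, and the two lie within the scatter of each other, so nothing separates them. Compound 1 is furthest away, with a lower number that lies beyond the scatter.

Compound 4, `CS(=O)(=O)c1cnc(O[C@H]2CC[C@H](OC3CCN(C(=O)C4(C(F)(F)F)CC4)CC3)CC2)cn1`, has not yet been measured. It differs from compound 3 by a group of 7 heavy atoms (4 carbon, 3 fluorine; one three-membered non-aromatic ring of carbon only) in place of a group of 5 heavy atoms (3 carbon, 1 oxygen, 1 fluorine; no ring), on a carbonyl carbon. For the measured compounds named here, no measured pair in this set exchanges the group on the carbonyl carbon, so there is no precedent for the size of this step. On that footing the expected step in this assay is a small one, not clearly beyond the scatter, with a slight lean towards a lower number. For compound 4 the estimate is 250 nM, with a range from 80 nM to 800 nM, which would mean an expected step of a 1.4-fold lower number from compound 3 to compound 4 (0.15 log units; within the scatter).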

Compound 4, half-maximal effective concentration: 1380 nM
Estimate against measurement, compound 4: 5.5-fold (0.74 log units) below; the whole stated range lies below it.
By their numbers in this assay, from the lowest: compound 1; then compounds 3 and 2 (each within the scatter of the next); then compound 4.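

For the compounds shown here, the group on the carbonyl carbon, whose other neighbour is an amide-type nitrogen in a ring, proves able to shift the number in this assay: placing 1-(trifluoromethyl)cyclopropyl there gives a 3.9-fold higher number from compound 3 to compound 4 (0.59 log units; beyond the scatter), whereas the earlier compounds offered no exchange at this position. The group that leaves carries a hydrogen-bond acceptor and has no ring, while the group that enters has a three-membered ring and no such acceptor, so this single exchange alters several features at once and cannot separate them. Nothing measured here accounts for the step.

On these data alone, how a plain cyclopropyl or an ethyl chain would read on this same carbonyl carbon remains open, and that would separate the ring from the trifluoromethyl. Also open, as far as these compounds go, is whether the step carries over to the other end of compound 1 or compound 2.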